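The source may hold more compounds than are shown below. What is called first, only, known or untested is meant among the compounds shown, and "the series" means these compounds.

Measured so far:
compound 1 `CC/N=C(\S)NCCCn1nc(-c2ccccc2)ccc1=O` — 39%
compound 2 `C/N=C(/NC#N)N(C)CCCCn1nc(-c2ccccc2)ccc1=O` — 27%

In a functional assay on the whole organism with Rattus norvegicus as the target, at a dose of 100 mg/kg (a higher number here means more inhibition at the dose given (going by the name of the read-out), a lower number less inhibition), compound 1 gives 39%, the higher of the two numbers. Compound 2 gives 27%, a gap beyond the usual scatter. Compound 3 `N#CNC(=N)NCCCn1nc(-c2ccccc2)ccc1=O` has not yet been measured. It differs from compound 1 by a group of 5 heavy atoms (2 carbon, 3 nitrogen; no ring) in place of a group of 5 heavy atoms (3 carbon, 1 nitrogen, 1 sulfur; no ring), on an amine nitrogen. Going by the values given here, no measured pair shows this exact change, so its effect is not known from the data. Among the compounds with values here, since compound 2, the only other measured compound, gives 27%, a modest downward step is expected, a number 7 percentage points lower from compound 1 to compound 3 (within the scatter). Compound 3 is therefore estimated at 32%, within 15% to 50%.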

Compound 3, a percentage reported as inhibition, in the whole organism at one dose (the size of the read-out at that dose, not a potency): 33.3%
Estimate against measurement, compound 3: 1.3 percentage points below; measured number inside the range.
By their numbers in this assay, from the lowest: compounds 2, 3 and 1 (each within the scatter of the next, the first and the last beyond it).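

Going by these compounds alone, the first single-place comparison concerns the group on an amine nitrogen. In this assay, replacing the sulfur-containing group with one of 2 carbon and 3 nitrogen atoms gives a number 5.7 percentage points lower from compound 1 to compound 3 (within the scatter). Sulfur is therefore not required at this position for a number that cannot be told apart from that of compound 1, although no data on hand explain this. Going by these compounds, it remains open whether a simple amine or a carboxylic acid in place of these groups would hold the number at this level.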